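Swapping 4-cyanophenyl for pyridin-4-yl in compound 4

The source may report more compounds than this note shows. Statements on the series, on what has been measured and on what is new or still open speak of the compounds shown alone.

Measured in a physicochemical assay for lipophilicity, measured as octanol-water partition; a lower number here means a more polar compound, a higher number a more lipophilic compound:
- Compound 1 `O=C(NNc1ccnc2cc(Cl)ccc12)c1ccccc1/N=C/c1ccc(Br)cc1`: 5.76
- Compound 2 `COc1ccc(/C=N/c2ccccc2C(=O)NNc2ccnc3cc(Cl)ccc23)cc1OC`: 4.97
- Compound 3 `N#Cc1ccc(/C=N/c2ccccc2C(=O)NNc2ccnc3cc(Cl)ccc23)cc1`: 4.83

Compound 3 stands at 4.83. Its nearest measured neighbour shows a number 0.14 log units lower from compound 2 to compound 3 (within the scatter), and its furthest shows a number 0.93 log units lower from compound 1 to compound 3 (beyond the scatter).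

The next compound, compound 4 (`O=C(NNc1ccnc2cc(Cl)ccc12)c1ccccc1/N=C/c1ccncc1`), carries pyridin-4-yl in place of 4-cyanophenyl on a carbon with a double bond to nitrogen.

All three measured steps change the group at this same place. Two were clear, a number 0.79 log units lower from compound 1 to compound 2 (beyond the scatter) and a number 0.93 log units lower from compound 1 to compound 3 (beyond the scatter), while a number 0.14 log units lower from compound 2 to compound 3 (within the scatter) shows that not every change here moves the number. Among the measured compounds shown here, no measured compound carries a ring with a hetero atom at this place, so the steps guide the size better than the direction. A modest step to a lower number in this assay is nevertheless expected, comparable to those from compound 1. The expected change is a number 0.53 log units lower from compound 3 to compound 4 (beyond the scatter). For compound 4 the estimated value is 4.3, with an expected range from 3.85 to 4.75.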

Compound 4, partition coefficient: 3.86
Beside the measured number, compound 4's estimate is 0.44 log units above it; low and high end bracket the measured number.
By their numbers in this assay, from the lowest: compound 4; then compounds 3 and 2 (each within the scatter of the next); then compound 1.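

Among the compounds shown here, at this place, on a carbon with a double bond to nitrogen, pyridin-4-yl is the first ring with a hetero atom, and it separates compound 4 clearly from two compounds that lie within the scatter of each other. In this assay the swap gives a number 0.97 log units lower from compound 3 to compound 4 (beyond the scatter) and a number 1.11 log units lower from compound 2 to compound 4 (beyond the scatter) as steps beyond that scatter. The step from the 4-bromophenyl compound is the largest seen at this place, with a number 1.90 log units lower from compound 1 to compound 4 (beyond the scatter) as its size, and it shows that changing an atom of the ring itself can move the number further than any change among the carbon-only rings did.

On these data alone, whether an amine or a carboxylic acid on the pyridine ring would take the number lower still remains open. Nothing measured here explains the size of these steps.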